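A decyl group added to the chain of compound 1

The source may hold more compounds than are shown below. What is called first, only, known or untested is meant among the compounds shown, and "the series" means these compounds.

Going by the values given here, in an ADME assay on CHO-K1 cells (Cricetulus griseus) for cytotoxicity, read by MTT assay, with a stated time of 24 h (a higher number here means a weaker inhibitor, a lower number a stronger inhibitor), compound 1 `CCCCCC(=O)Nc1nnc(S[C@@H]2O[C@H](COC(C)=O)[C@H](OC(C)=O)[C@H](OC(C)=O)[C@H]2OC(C)=O)s1` gives 24400 nM and that is the only number so far. Compound 2 `CCCCCCCC/C=C\CCCCCCCCCCCC(=O)Nc1nnc(S[C@@H]2O[C@H](CO)[C@H](O)[C@H](O)[C@H]2O)s1` is reported as "not active" (no number reported) with no figure attached, so compound 1 cannot yet be ranked against anything. Compound 3 `CCCCCCCCCCCCCCCC(=O)Nc1nnc(S[C@@H]2O[C@H](COC(C)=O)[C@H](OC(C)=O)[C@H](OC(C)=O)[C@H]2OC(C)=O)s1` differs from compound 1 by decyl in place of hydrogen on a saturated chain carbon, five bonds along the chain from a carbonyl carbon in one place: decyl in place of hydrogen on a saturated chain carbon, five bonds along the chain from a carbonyl carbon. Among the compounds with values here, no measured pair shows what such a change does, so any forecast is loose. Within the data shown here, the one slim hint is compound 2 at "not active" (no number reported) even though it differs from compound 1 in more than one place. A modest move toward weaker inhibition is therefore expected, an estimated 2.0-fold higher number from compound 1 to compound 3 (0.31 log units; beyond the scatter) close to the usual scatter. Compound 3 is expected at 50000 nM within a range of 15000 nM to 170000 nM in this assay when tested.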

Compound 3, half-maximal inhibitory concentration: 90400 nM
The estimate for compound 3 lay 1.8-fold (0.26 log units) below the measured number; low and high end bracket the measured number.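

Going by these compounds alone, this is the first measured step at this position. In this assay decyl in place of hydrogen on a saturated chain carbon, five bonds along the chain from a carbonyl carbon, gives a 3.7-fold higher number from compound 1 to compound 3 (0.57 log units; beyond the scatter) and so moves the series toward weaker inhibition. The chain can therefore carry this large addition with a modest change in the number, but nothing measured here gives a reason for that change.

A single step cannot show whether the number climbs steadily with chain length or changes abruptly at some length, and a butyl group at the same place, or a decyl chain ending in a carboxylic acid or an amine, could help settle how much depends on length and how much on the chain's end. Compound 2 differs from compound 1 in more than one place, so it leaves open what the chain alone does when the sugar hydroxyl groups are free.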